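The source may hold more compounds than are shown below. What is called first, only, known or untested is meant among the compounds shown, and "the series" means these compounds.

Compound 1 `CCCn1ccnc1-c1cc(OC)c(OC)c(OC)c1`: in a functional assay on HT-29 cells (Homo sapiens) for antiproliferative activity, read by MTT assay, with a stated time of 72 h (on this read-out lower numbers stand for stronger inhibition and higher numbers for weaker inhibition), compound 1 gives only the limit > 100000 nM, not a number.
Compound 2 `COc1cc(-c2nccn2-c2ccc3cc[nH]c3c2)cc(OC)c1OC`: in this assay compound 2 gives 3600 nM.

Compound 1 stands at the limit of this assay, as the limit of > 100000 nM in this assay, at which 1 of the 2 values shown sits, shows; nothing more than that limit is known for it. Only a limit is recorded for compound 1. Going by the values given here, no measured step between compound 1 and compound 2 can therefore be stated, and what the two show is simply that compound 2 has a number while compound 1 has none.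

Compound 3 `COc1cc(-c2nccn2-c2ccc(F)cc2)cc(OC)c1OC` has not yet been measured in this assay. It differs from compound 1 by 4-fluorophenyl in place of propyl on an aromatic nitrogen. Compound 2 gives 3600 nM in this assay. With that number in view, compound 3 is expected to give a measurable number, a step of an at least 10-fold lower number from compound 1 to compound 3 (1.00 log units; beyond the scatter) in the direction of stronger inhibition. In this assay compound 3 is estimated at 10000 nM, with a range from 2000 nM to 60000 nM.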

Compound 3, half-maximal inhibitory concentration: 29300 nM
For compound 3 the middle estimate is 2.9-fold (0.47 log units) below the measured one, within the range that was stated.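

Going by these compounds alone, replacing propyl with 4-fluorophenyl on the aromatic nitrogen gives the first step that can be read at this position in this assay: an at least 3.4-fold lower number from compound 1 to compound 3 (0.53 log units; beyond the scatter). The change of group at this nitrogen therefore moves the read-out beyond the scatter, towards stronger inhibition, and it turns a limit into a number. The true size of the step stays unknown because compound 1 has only a limit and no number: the limit of > 100000 nM in this assay, at which 1 of the 3 values shown sits.

As far as these compounds go, it remains open whether the step belongs to the six-membered aromatic ring itself or to its fluorine, which a plain phenyl group on the same nitrogen could separate. Also open, from the compounds shown here alone, is what a benzyl group, an amine-bearing chain or a longer chain such as butyl would give at this position.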